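From Hydroxy to Dimethylamino on a Compound Without a Number

A few compounds are considered here, and "the series" means these few. Any claim that something is new, unique, unknown or untested is made for them only; others in the source may bear on it.

In a functional assay on HT-22 cells (Mus musculus), read by MTT assay, with a stated time of 24 h (on this read-out lower numbers stand for an effect already at smaller amounts and higher numbers for an effect only at larger amounts of compound), compound 1 (`COc1cc(-c2cc(OC)c3ccccc3n2)ccc1O`) gives 500 nM as its half-maximal concentration. Compound 2 (`COc1cc(-c2ccc(O)cc2)nc2ccccc12`) is reported as "not active" (no number reported) and so has no single number to start from. Compound 3 (`COc1cc(-c2ccc(N(C)C)cc2)nc2ccccc12`) has not been measured yet. The change dimethylamino in place of hydroxy on an aromatic carbon puts dimethylamino in place of hydroxy on an aromatic carbon, para to a large group. In this assay a step towards a measurable effect is expected, though its size is uncertain and a second inactive result remains quite possible. The estimated value for compound 3 is 1500 nM (from 300 nM to 8000 nM).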

Compound 3, half-maximal effective concentration: 60 nM
For compound 3 the middle estimate is 25-fold (1.40 log units) above the measured one; measured number below the stated range.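

In this assay, within the data shown here, compound 2 is recorded as "not active" (no number reported) while compound 3 gives 60 nM, so no step between them can be read. The compounds shown leave open how much dimethylamino in place of hydroxy shifts the value, and nothing measured here offers an explanation for the result.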